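Working notes: from compound 3 to compound 4

This account rests on a few compounds, and the source may have more. Where it says the series, first, only, none or still open, it means among the compounds named here.

In a functional assay on KB 3-1 cells (Homo sapiens) for cytotoxicity, read by MTT assay, with a stated time of 68 h (a lower number here means a stronger inhibitor, a higher number a weaker inhibitor), compound 1 `Nc1cccc(-c2cccc(NC(=O)C(Cl)Cl)c2)c1` gives 26100 nM. Among the measured compounds shown here, compound 3 `O=C(Nc1cccc(-c2ccc(F)cc2)c1)C(Cl)Cl` gives 26200 nM, which lies within the scatter of the value for compound 1, and these are the only two numbers so far. Compound 2 `O=C(Nc1cccc(-c2cccs2)c1)C(Cl)Cl` reads > 50000 nM, which is a limit of this assay and not a number.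

Compound 4 `O=C(Nc1cccc(-c2ccccc2)c1)C(Cl)Cl` has hydrogen in place of fluoro on an aromatic carbon, para to a large group: hydrogen in place of fluoro on an aromatic carbon. For the measured compounds named here, no measured pair shows this change, so the starting point is compound 3 at 26200 nM, and no step beyond the scatter is expected. The estimated change is a 1.1-fold higher number from compound 3 to compound 4 (0.06 log units; within the scatter). Compound 4 is expected at 30000 nM, with an estimated range of 15000 nM to 50000 nM.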

Compound 4, half-maximal inhibitory concentration: 46800 nM
Estimate against measurement, compound 4: 1.6-fold (0.19 log units) below; low and high end bracket the measured number.
By their numbers in this assay, from the lowest: compounds 1, 3 and 4 (each within the scatter of the next). At a limit, above all of these: compound 2.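

In this assay, hydrogen in place of fluoro gives a 1.8-fold higher number from compound 3 to compound 4 (0.25 log units; within the scatter) and hydrogen in place of amino gives a 1.8-fold higher number from compound 1 to compound 4 (0.25 log units; within the scatter), so neither group separates from hydrogen on this aromatic carbon beyond the scatter. Phenyl in place of thiophen-2-yl gives an at least 1.0-fold lower number from compound 2 to compound 4 (0.02 log units; that floor lies within the scatter), and that step gives only a floor. Compound 2 stands at a limit of the assay and not at a number: the limit of > 50000 nM in this assay, at which 1 of the 4 values shown sits.

The compounds shown leave open whether a carboxylic acid or a methoxy group on that aromatic carbon would give a step beyond the scatter.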